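Chloro in place of bromo: working notes on the series

The source may report more compounds than this note shows. Statements on the series, on what has been measured and on what is new or still open speak of the compounds shown alone.

Compound 1 `Cc1cc(C)cc(S(=O)(=O)n2c(SCC(=O)Nc3ccccc3C)nc3ccccc32)c1`: 6150 nM
Compound 2 `Cc1cc(C)cc(S(=O)(=O)n2c(SCC(=O)Nc3ccccc3C(=O)O)nc3ccccc32)c1`: 25200 nM
Compound 3 `Cc1cc(C)cc(S(=O)(=O)n2c(SCC(=O)Nc3ccccc3Br)nc3ccccc32)c1`: >= 235000 nM, a limit

All three values come from an ADME assay on MT4 cells (Homo sapiens) for cytotoxicity, read by MTT assay, with a stated time of 5 days; a higher number here means that more compound is tolerated, a lower number that less compound is tolerated. Compound 3 returns only a limit and no number (the limit of >= 235000 nM in this assay, at which 1 of the 3 values shown sits). It still stands clear of the other two: the record shows an at least 38-fold higher number from compound 1 to compound 3 (1.58 log units; beyond the scatter) and an at least 9.3-fold higher number from compound 2 to compound 3 (0.96 log units; beyond the scatter).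

Compound 4 `Cc1cc(C)cc(S(=O)(=O)n2c(SCC(=O)Nc3ccccc3Cl)nc3ccccc32)c1` carries chloro in place of bromo on an aromatic carbon, ortho to a large group (chloro in place of bromo on an aromatic carbon). Going by the values given here, no measured step brings in chloro. The closest evidence is the set of changes at this same place, where the steps into the bromo compound are large or at least modest, and a 4.1-fold higher number from compound 1 to compound 2 (0.61 log units; beyond the scatter) is modest. This place therefore responds to substitution, so a modest step to a lower number is expected in this assay, and a second limit remains possible. The expected change is an at least 3.9-fold lower number from compound 3 to compound 4 (0.59 log units; beyond the scatter). For compound 4 the estimated value is 60000 nM, with an expected range from 10000 nM to 250000 nM.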

Compound 4, half-maximal cytotoxic concentration: 107000 nM
Compound 4: the middle estimate sits 1.8-fold (0.25 log units) below what was measured; low and high end bracket the measured number.
By their numbers in this assay, from the lowest: compound 1; then compound 2; then compound 4. At a limit, above all of these: compound 3.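

In this assay, going by these compounds alone, compound 4 gives the first number for a halogen at this place, and it stands clear of both other substituents: a 17-fold higher number from compound 1 to compound 4 (1.24 log units; beyond the scatter), and a 4.2-fold higher number from compound 2 to compound 4 (0.63 log units; beyond the scatter). Among the four compounds, both halogens therefore lie above methyl and carboxy, and no compound shown goes against this, while the exchange of one halogen for the other still registers: an at least 2.1-fold lower number from compound 3 to compound 4 (0.34 log units; beyond the scatter). Compound 3 remains a limit, so the full size of that step stays unknown: the limit of >= 235000 nM in this assay, at which 1 of the 4 values shown sits.

The compounds shown leave open where fluoro, iodo or an amine would fall at this same aromatic carbon. They also leave open whether the order from chloro to bromo carries on to iodo, and whether the same order holds with a longer chain in place of the halogen.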